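The source may report more compounds than this note shows. Statements on the series, on what has been measured and on what is new or still open speak of the compounds shown alone.

Compound 1 `Cc1ccc(-n2nncc2CN2C(=O)C3(C(C#N)=C(N)Oc4c3c3nc5ccccc5nc3c3ccccc43)c3ccccc32)cc1C` and compound 2 `N#CC1=C(N)Oc2c(N)cc3nc4ccccc4nc3c2C12C(=O)N(Cc1cnnn1-c1cccc(Br)c1)c1ccccc12` share the same core and have both been tested in an ADME assay on HUVEC cells (Homo sapiens) for antiproliferative activity, read by MTT assay, with a stated time of 48 h; a lower number here means a stronger inhibitor, a higher number a weaker inhibitor. Compound 1 gives > 50000 nM in this assay, which is a limit of the assay rather than a number. Compound 2 likewise gives > 50000 nM in this assay, again a limit of the assay and not a measured number. Compound 2 therefore stands at the limit of > 50000 nM in this assay, at which 2 of the 2 values shown sit, and no number separates it from compound 1. Compound 3 `Cc1ccc(-n2nncc2CN2C(=O)C3(C(C#N)=C(N)Oc4c(N)cc5nc6ccccc6nc5c43)c3ccccc32)cc1C` has not yet been measured in this assay. It differs from compound 2 in one place: 3,4-dimethylphenyl in place of 3-bromophenyl on an aromatic nitrogen. For the measured compounds named here, the same 3,4-dimethylphenyl group on the aromatic nitrogen is already present in compound 1, which also sits at the limit, so the exchange between 3-bromophenyl and 3,4-dimethylphenyl gives no sign of a step that would rise above the usual scatter. Compound 3 is therefore expected to remain at the limit, and the step that the limit leaves unreadable from compound 2 to compound 3 is estimated to be none beyond the scatter. Compound 3 is estimated at 60000 nM, within a range from 30000 nM to 150000 nM.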

Compound 3, half-maximal inhibitory concentration: > 50000 nM
Compound 3 ended at the assay's limit; the forecaster's own chance of this, stated with the estimate: 85%; the middle value lies beyond the limit too.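

In this assay compound 3 gives > 50000 nM, which is a limit of the assay and not a number. Compound 2 sits at the same limit, so no step can be read between compound 2 and compound 3. The compounds shown leave open whether 3-bromophenyl and 3,4-dimethylphenyl differ at all in this assay.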